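Compound 1 to compound 4: methyl for oxolan-3-yl

The source may report more compounds than this note shows. Statements on the series, on what has been measured and on what is new or still open speak of the compounds shown alone.

In a functional assay on MCF7 cells (Homo sapiens) for cytotoxicity, read by MTT assay, with a stated time of 72 h (a lower number here means a stronger inhibitor, a higher number a weaker inhibitor), compound 1 `O=C(N/N=C/c1ccc(F)cc1)Nc1cc2c(Nc3ccc(F)c(Cl)c3)ncnc2cc1O[C@H]1CCOC1` gives 28200 nM, which places it at the high end of the three numbers, level with compound 2 `COc1ccc(/C=N/NC(=O)Nc2cc3c(Nc4ccc(F)c(Cl)c4)ncnc3cc2O[C@H]2CCOC2)cc1` at 27300 nM. Compound 3 `O=C(N/N=C/c1ccc(O)cc1O)Nc1cc2c(Nc3ccc(F)c(Cl)c3)ncnc2cc1O[C@H]1CCOC1` stands apart at 5350 nM.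

Compound 4 `COc1cc2ncnc(Nc3ccc(F)c(Cl)c3)c2cc1NC(=O)N/N=C/c1ccc(F)cc1` differs from compound 1 as follows: methyl in place of oxolan-3-yl on an oxygen on an aromatic ring. In words, it has methyl in place of oxolan-3-yl on an oxygen on an aromatic ring.

The measured steps all concern the group on the carbon with a double bond to nitrogen, not this oxygen. One step, a 1.0-fold lower number from compound 1 to compound 2 (0.01 log units; within the scatter), stayed within the scatter, while a 5.3-fold lower number from compound 1 to compound 3 (0.72 log units; beyond the scatter) and a 5.1-fold lower number from compound 2 to compound 3 (0.71 log units; beyond the scatter) were modest. None of them measures the present change, so they give only a rough idea of step size and no direction. No step beyond the scatter is therefore expected in this assay, and the starting point remains compound 1 at 28200 nM.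

The expected change is a 1.1-fold lower number from compound 1 to compound 4 (0.05 log units; within the scatter).

Compound 4 is estimated at 25000 nM, with an expected range of 10000 nM to 60000 nM.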

Compound 4, half-maximal inhibitory concentration: 35100 nM
Beside the measured number, compound 4's estimate is 1.4-fold (0.15 log units) below it, within the range that was stated.
By their numbers in this assay, from the lowest: compound 3; then compounds 2, 1 and 4 (each within the scatter of the next).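

In this assay the oxygen on the aromatic ring now has its first reading: a 1.2-fold higher number from compound 1 to compound 4 (0.10 log units; within the scatter). Oxolan-3-yl, with its five-membered non-aromatic ring and defined stereocentre, and methyl cannot be told apart here with 4-fluorophenyl on the carbon with a double bond to nitrogen, and the steps beyond the scatter remain those that lead to compound 3 at that other site. No measurement bears on the reason for this result.

As far as these compounds go, it remains open whether methyl and oxolan-3-yl would also read alike with the 2,4-dihydroxyphenyl group of compound 3 in place. Also open, from the compounds shown here alone, is how this oxygen would respond to a longer chain ending in an amine or a carboxylic acid.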